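The source may report more compounds than this note shows. Statements on the series, on what has been measured and on what is new or still open speak of the compounds shown alone.

Measured so far:
Compound 1, `CCc1nnc(SC)n1N1C(=O)c2ccccc2C1=O` — > 200000 nM
Compound 2, `CCCc1nnc(SCC(=O)c2ccccc2)n1N1C(=O)c2ccccc2C1=O` — > 200000 nM

Compound 1 carries a methylthio group on the shared core and a two-carbon chain. In a functional assay on MKN-45 cells (Homo sapiens) for cytotoxicity, read by MTT assay, with a stated time of 48 h (on this read-out higher numbers stand for weaker inhibition and lower numbers for stronger inhibition), compound 1 gives > 200000 nM, which is a limit of the assay and not a number. Compound 2 carries a three-carbon chain and a benzoylmethylthio group. In this assay compound 2 gives > 200000 nM, again a limit rather than a number. Compound 2 therefore stands at the edge of what the assay can report, and both values shown sit at the same place: the limit of > 200000 nM in this assay, at which 2 of the 2 values shown sit.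

Compound 3, `CCCc1nnc(SC)n1N1C(=O)c2ccccc2C1=O`, is the next compound and is not yet measured. It differs from compound 2 in one place: hydrogen in place of benzoyl on a saturated chain carbon bound to a sulfur. Compound 3 thus keeps the three-carbon chain of compound 2 but carries the methylthio group seen in compound 1.

Among the compounds with values here, no measured pair isolates this change, so no step size is known. Since compound 1 and compound 2 both sit at the limit, the step from compound 2 to compound 3 is expected to be none beyond the scatter: a step that the limit leaves unreadable from compound 2 to compound 3. The author expects compound 3 to give about 300000 nM in this assay, within 100000 nM to 1000000 nM, most likely reported again as a limit.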

Compound 3, half-maximal inhibitory concentration: > 200000 nM
Compound 3: only a limit was reported (the forecaster's own chance of this, stated with the estimate: 85%); the middle value is on the limit's open side.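

Within the data shown here, no step between compound 1, compound 2 and compound 3 can be read in this assay, because each value is a limit of the assay and not a number: the limit of > 200000 nM in this assay, at which 3 of the 3 values shown sit.

The compounds shown leave open whether the chain or the group on sulfur alters cytotoxicity at all, since none of them gives a value that can be compared.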